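A few compounds are considered here, and "the series" means these few. Any claim that something is new, unique, unknown or untested is made for them only; others in the source may bear on it.

In a functional assay on A549 cells (Homo sapiens) for cytotoxicity, read by sulforhodamine B assay, with a stated time of 72 h (a higher number here means a weaker inhibitor of growth, a lower number a stronger inhibitor of growth), compound 1 `C=C1CC[C@@H]2[C@](C)(CCC[C@]2(C)C(=O)O)[C@H]1CCc1ccc2c(c1)C(=O)C=CC2=O` stands at > 7400 nM as a limit of the assay and not a number. Among the compounds with values here, compound 2 `C=C1CC[C@@H]2[C@](C)(CCC[C@]2(C)C(=O)O)[C@H]1CCC1=CCc2c(OC(C)=O)ccc(OC(C)=O)c2C1` gives 2500 nM as the only actual number so far in this assay for this series. Compound 3 `C=C1CC[C@@H]2[C@](C)(CCC[C@]2(C)C(=O)OC)[C@H]1CCC1=CCc2c(OC(C)=O)ccc(OC(C)=O)c2C1` differs from compound 2 by methyl in place of hydrogen on an oxygen next to a carbonyl group with methyl in place of hydrogen on an oxygen next to a carbonyl group, so carboxy becomes methoxycarbonyl. Within the data shown here, no measured step shows what this change does, so only a small move toward stronger growth inhibition, not clearly beyond the scatter, is expected, with a 1.4-fold lower number from compound 2 to compound 3 (0.14 log units; within the scatter) as the estimated step. For compound 3 the estimated value is 1800 nM and the expected range runs from 600 nM to 5500 nM here.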

Compound 3, concentration for 50% growth inhibition: 510 nM
Estimate against measurement, compound 3: 3.5-fold (0.55 log units) above; measured number below the stated range.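

In this assay, changing carboxy to methoxycarbonyl gives a 4.9-fold lower number from compound 2 to compound 3 (0.69 log units; beyond the scatter) and so shows that the hydrogen on this oxygen can be replaced by methyl without any loss of growth inhibition. At this position, the free carboxy group is therefore not needed for activity in these cells. Nothing measured here accounts for the size of this step. Still open, going by these compounds, is whether a longer chain on this oxygen would go further, and whether an amide in place of the ester would keep the gain.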